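Swapping One Aromatic Group in Compound 2

The source may report more compounds than this note shows. Statements on the series, on what has been measured and on what is new or still open speak of the compounds shown alone.

Measured in an ADME assay on L6 cells (Rattus norvegicus) for cytotoxicity; a higher number here means a weaker inhibitor, a lower number a stronger inhibitor:
- Compound 1 `O=C(CN1CCN(c2ccc(Cl)cc2)CC1)N1CCN(c2ccc(Cl)cc2)CC1`: 116000 nM
- Compound 2 `COc1ccc(N2CCN(C(=O)Cn3cnc([N+](=O)[O-])n3)CC2)cc1`: 133000 nM
- Compound 3 `O=C(CN1CCN(c2ccc(C(F)(F)F)cc2)CC1)N1CCN(c2ccc(C(F)(F)F)cc2)CC1`: 31700 nM

For the measured compounds named here, only three numbers are available so far. Compound 2 belongs to the top of this small set, together with compound 1, and the gap between those two lies within the usual scatter of repeated measurements. Compound 3 has a lower number than compound 2, and that gap lies beyond the scatter.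

The next compound to be tested is compound 4 `O=C(Cn1cnc([N+](=O)[O-])n1)N1CCN(c2ccccn2)CC1`. It puts pyridin-2-yl in place of 4-methoxyphenyl on an amine nitrogen in a ring. Going by the values given here, no pair of measured compounds shows a change in one place only, so the data offer no direct guide to the effect of this swap. The best starting point is therefore compound 2 at 133000 nM, the measured compound that shares the rest of the structure with compound 4.

In this assay, no shift beyond the scatter is expected, and the estimated step is a 1.1-fold higher number from compound 2 to compound 4 (0.05 log units; within the scatter). The estimated value for compound 4 is 150000 nM, with an expected range from 60000 nM to 320000 nM.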

Compound 4, half-maximal inhibitory concentration: 173000 nM
Estimate against measurement, compound 4: 1.2-fold (0.06 log units) below, and the stated range covers the measured number.
By their numbers in this assay, from the lowest: compound 3; then compounds 1, 2 and 4 (each within the scatter of the next).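

In this assay, for the compounds shown here, the first pair of compounds that differ in one place gives a 1.3-fold higher number from compound 2 to compound 4 (0.11 log units; within the scatter), so this swap on the amine nitrogen in the ring makes no difference that this assay can distinguish from repeat-to-repeat variation. At this position, the aromatic group can go from a ring of carbon only, bearing a methoxy group, to a ring with one hetero atom, and from 8 heavy atoms to 6, without a shift beyond the scatter, though this rests on a single pair. Nothing measured here offers an explanation for this outcome.

As far as these compounds go, what remains open is whether other groups on the same nitrogen, such as an unsubstituted phenyl ring, pyridin-4-yl or a short alkyl chain, would also leave the number within the scatter of compound 2. This one pair also cannot show whether the same swap would have so small an effect on the cores of compound 1 and compound 3, which differ from compound 2 in more than one place.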